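Cyclopentyl for cyclopropyl on a shared core

The compounds below may be only part of what the source reports. "The series", "measured", "known", "first", "only" and "open" are said of these compounds alone.

Of the compounds shown here, three built on one shared core have been measured in an assay on membranes from Chem-1 cells for displacement of a labelled ligand from prostaglandin E2 receptor EP3 subtype (Homo sapiens), read by scintillation counting, with a stated time of 2 h; on this read-out higher numbers stand for weaker inhibition and lower numbers for stronger inhibition. Compound 1 `CC(C)[C@@H](C[C@H]1SC(=O)NC1=O)c1ccc(-c2ccc3cccc(F)c3c2)[nH]c1=O` gives 6 nM, compound 2 `O=C1NC(=O)/C(=C/C(c2ccc(-c3ccc4cccc(F)c4c3)[nH]c2=O)C2CC2)O1` gives 22 nM, and compound 3 `CC(C)[C@@H](c1ccc(-c2ccc3cccc(F)c3c2)[nH]c1=O)[C@@H]1OC(=O)NC1=O` gives 85 nM. Compound 2 therefore stands second highest of the three: compound 1 sits at a lower number and compound 3 at a higher one, and both gaps lie beyond the usual scatter of this assay. For the measured compounds named here, none of these three differ from one another in a single place, so no single step among the measured compounds is known.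

Compound 4 `O=C1NC(=O)/C(=C/C(c2ccc(-c3ccc4cccc(F)c4c3)[nH]c2=O)C2CCCC2)O1` has not yet been measured. It differs from compound 2 in one place: cyclopentyl in place of cyclopropyl on a saturated chain carbon bound to an aromatic carbon and a double-bonded chain carbon. Going by the values given here, nothing among the measured compounds shows the effect of this change on its own, so the expected step is small and its direction open. The step from compound 2 to compound 4 is estimated at a 1.1-fold higher number from compound 2 to compound 4 (0.06 log units; within the scatter), that is, none beyond the scatter. On that basis compound 4 is expected to give about 25 nM in this assay, within a range of 8 nM to 80 nM.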

Compound 4, inhibition constant: 9 nM
For compound 4 the middle estimate is 2.8-fold (0.44 log units) above the measured one; measured number inside the range.
By their numbers in this assay, from the lowest: compounds 1 and 4 (each within the scatter of the next); then compound 2; then compound 3.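

In this assay the size of the carbon ring at this position turns out to matter: cyclopentyl in place of cyclopropyl on a saturated chain carbon bound to an aromatic carbon and a double-bonded chain carbon gives a 2.4-fold lower number from compound 2 to compound 4 (0.39 log units; beyond the scatter), a modest step. This pair is the first single change among the compounds shown, and it shows that the larger ring is accepted here and goes with stronger inhibition rather than weaker. Nothing at hand says why the number falls with this change.

As far as these compounds go, two ring sizes do not make a trend, so it remains open whether cyclobutyl or cyclohexyl on this carbon would fall in line with them. Also open, from the compounds shown here alone, is whether the same change would carry over to the cores of compound 1 and compound 3.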